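A few compounds are considered here, and "the series" means these few. Any claim that something is new, unique, unknown or untested is made for them only; others in the source may bear on it.

In a functional assay on SK-OV-3 cells (Homo sapiens) for inhibition, read by CCK-8 assay, with a stated time of 70 h (a higher number here means a weaker inhibitor, a lower number a stronger inhibitor), compound 1 `COc1ccc(OCCOCCNC2CCCC2)cc1` gives 99100 nM, which is very weak inhibition. Compound 2 `O=C(O)c1cccc(COc2ccc(OCCOCCNC3CCCC3)cc2)c1` reads > 100000 nM, and this is a limit of the assay, not a number. Overall, the results so far include (the limit of > 100000 nM in this assay, at which 1 of the 2 values shown sits).

Compound 3 `COc1ccc(COc2ccc(OCCOCCNC3CCCC3)cc2)cc1` is the next structure to consider. The change from compound 2 is 4-methoxyphenyl in place of 3-carboxyphenyl on a saturated chain carbon bound to an oxygen on an aromatic ring. In words, it places 4-methoxyphenyl in place of 3-carboxyphenyl on a saturated chain carbon bound to an oxygen on an aromatic ring.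

For the measured compounds named here, only one measured step bears on this position, a number no lower from compound 1 to compound 2 (the limit leaves the size open). As far as these compounds go, its size stays unknown, so it offers a direction at best and no firm scale. Neither measured compound shows strong inhibition, so a large gain would have no support. A small step toward a lower number is expected in this assay, and it may not exceed the usual scatter. The estimated change is an at least 1.6-fold lower number from compound 2 to compound 3 (0.22 log units; that floor lies within the scatter). For compound 3 the expected value is 60000 nM, with an estimated range from 20000 nM to 100000 nM.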

Compound 3, half-maximal inhibitory concentration: 15700 nM
Estimate against measurement, compound 3: 3.8-fold (0.58 log units) above; measured number outside the range, below it.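

Here the position shows a gain for the first time: the 4-methoxyphenyl group gives a 6.3-fold lower number from compound 1 to compound 3 (0.80 log units; beyond the scatter) in this assay. The choice of group at this place matters as well, as exchanging 3-carboxyphenyl for 4-methoxyphenyl gives an at least 6.3-fold lower number from compound 2 to compound 3 (0.80 log units; beyond the scatter). The size of that second step is only a floor, because the reading for compound 2 is a limit of the assay and not a number: the limit of > 100000 nM in this assay, at which 1 of the 3 values shown sits.

With only two groups shown at this place, it remains open whether the gain comes from the phenyl ring itself, from the methoxy group or from where that group sits on the ring. An unsubstituted phenyl, a 3-methoxyphenyl or a 4-chlorophenyl at the same carbon would help to separate these possibilities, and whether any group here can go far beyond compound 3, which reads 15700 nM, is still unanswered.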